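A few compounds are considered here, and "the series" means these few. Any claim that something is new, unique, unknown or untested is made for them only; others in the source may bear on it.

Measured compounds:

Compound 1 `CC(C)=CC[C@@H](OC(=O)CCO)C1=CC(=O)c2c(O)ccc(O)c2C1=O` gives 67600 nM in a functional assay on HeLa cells (Homo sapiens) for cytotoxicity, read by MTT assay; a lower number here means a stronger inhibitor, a higher number a weaker inhibitor.
Compound 2 `CCCC(O)CC(=O)O[C@H](CC=C(C)C)C1=CC(=O)c2c(O)ccc(O)c2C1=O` gives 59300 nM in this assay.
Compound 3 `COC(C)CO[C@H](CC=C(C)C)C1=CC(=O)c2c(O)ccc(O)c2C1=O` gives 53400 nM in this assay.

Compound 2 stands second highest of the three numbers, though all three sit within the scatter of one another: the nearest is compound 3, a 1.1-fold lower number from compound 2 to compound 3 (0.05 log units; within the scatter), and the furthest is compound 1, a 1.1-fold lower number from compound 1 to compound 2 (0.06 log units; within the scatter). The unmeasured compound 4 `CC(=O)OC(C)CO[C@H](CC=C(C)C)C1=CC(=O)c2c(O)ccc(O)c2C1=O` differs from compound 2 in one place: 2-acetoxypropyl in place of (2-hydroxypentyl)carbonyl on an oxygen on a saturated carbon.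

For the measured compounds named here, two measured steps bear on this change, both at the same oxygen on a saturated carbon. In one, a 1.1-fold lower number from compound 2 to compound 3 (0.05 log units; within the scatter); in the other, a 1.3-fold lower number from compound 1 to compound 3 (0.10 log units; within the scatter). Neither step left the scatter, and the whole set spans a narrow band. Going by the values given here, the change to compound 4 again replaces the acyl group on that oxygen with an alkyl group bearing an ester, and there is no step in the data that moved the number appreciably. Compound 4 is therefore expected to show no step beyond the scatter, a 1.1-fold lower number from compound 2 to compound 4 (0.02 log units; within the scatter). The estimate for compound 4 in this assay is 56000 nM, with a range from 28000 nM to 112000 nM.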

Compound 4, half-maximal inhibitory concentration: 40100 nM
Compound 4: middle estimate off by 1.4-fold (0.15 log units), on the high side, and the stated range covers the measured number.
By their numbers in this assay, from the lowest: compounds 4, 3, 2 and 1 (each within the scatter of the next).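

In this assay, 2-acetoxypropyl in place of (2-hydroxypentyl)carbonyl on this oxygen gives a small step (a 1.5-fold lower number from compound 2 to compound 4 (0.17 log units; within the scatter)), and acetyl in place of methyl on the oxygen of the side chain gives another (a 1.3-fold lower number from compound 3 to compound 4 (0.12 log units; within the scatter)). Even the largest gap now seen in the set, with 2-acetoxypropyl in place of (2-hydroxyethyl)carbonyl (a 1.7-fold lower number from compound 1 to compound 4 (0.23 log units; within the scatter)), stays within the scatter, so a second ester group on the alkyl chain leaves the number in the same narrow band as the other three compounds. No supporting measurement accounts for the numbers at this position.

On these data alone, whether an amine or a carboxylic acid on this side chain would move the number beyond the scatter remains open. So does the effect of a much longer chain, or of a bare hydroxyl group at this oxygen.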